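The source may hold more compounds than are shown below. What is called first, only, known or untested is meant among the compounds shown, and "the series" means these compounds.

Of the compounds shown here, three built on one shared core have been measured in a functional assay on NCI-H460 cells (Homo sapiens) for positive allosteric modulation, read by MTT assay, with stated times of 2 h and 72 h, tested at 10 uM; on this read-out higher numbers stand for weaker inhibition and lower numbers for stronger inhibition. Compound 1 `CCCc1ccc(C(=O)Nc2ccccc2-c2nnn(-c3cccc(OC)c3)n2)cc1` gives 121 nM, compound 2 `COc1cccc(-n2nnc(-c3ccccc3NC(=O)c3ccc(N)cc3)n2)c1` gives 211 nM, and compound 3 `COc1cccc(-n2nnc(-c3ccccc3NC(=O)c3ccc(N=[N+]=[N-])cc3)n2)c1` gives 415 nM. Among the measured compounds shown here, compound 3 sits clear of only one neighbour: the gap of a 3.4-fold higher number from compound 1 to compound 3 (0.54 log units; beyond the scatter) is a modest move towards weaker inhibition, while a 2.0-fold higher number from compound 2 to compound 3 (0.29 log units; within the scatter) does not separate the pair. The remaining step, a 1.7-fold higher number from compound 1 to compound 2 (0.24 log units; within the scatter), does not separate its pair either.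

The next compound is compound 4 `COc1cccc(-n2nnc(-c3ccccc3NC(=O)Nc3ccc([N+](=O)[O-])cc3)n2)c1`, and the change is (4-nitrophenyl)amino in place of 4-azidophenyl on a carbonyl carbon. In words, this puts (4-nitrophenyl)amino in place of 4-azidophenyl on a carbonyl carbon. For the measured compounds named here, all the measured steps exchange one group on an aromatic carbon, so none of them tests this larger swap directly. They offer only indirect guidance, and the largest of them is the modest 3.4-fold higher number from compound 1 to compound 3 (0.54 log units; beyond the scatter). A shift beyond the scatter is therefore not expected in either direction in this assay, although the uncertainty is wide. The estimated change is a 1.4-fold lower number from compound 3 to compound 4 (0.14 log units; within the scatter). For compound 4 the expected value is 300 nM, with an estimated range from 80 nM to 1200 nM.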

Compound 4, half-maximal inhibitory concentration: 113 nM
Compound 4: middle estimate off by 2.7-fold (0.42 log units), on the high side; low and high end bracket the measured number.
By their numbers in this assay, from the lowest: compounds 4, 1, 2 and 3 (each within the scatter of the next, the first and the last beyond it).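

In this assay, among the compounds shown here, the swap on the carbonyl carbon gives a 3.7-fold lower number from compound 3 to compound 4 (0.56 log units; beyond the scatter) and is the first measured change away from an aromatic carbon, showing that the whole group on this carbonyl carbon can be exchanged without losing inhibition. The entering (4-nitrophenyl)amino brings a hydrogen-bond donor that 4-azidophenyl lacks, yet the other two comparisons, a 1.9-fold lower number from compound 2 to compound 4 (0.27 log units; within the scatter) and a 1.1-fold lower number from compound 1 to compound 4 (0.03 log units; within the scatter), both stay within the scatter, so on this read-out it is not separated from 4-aminophenyl or 4-propylphenyl, and only 4-azidophenyl stands apart from it. Nothing measured here gives a reason for the step from 4-azidophenyl.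

The swap alters two things at once, the amino link to the carbonyl carbon and the nitro group in place of azido, so the compounds shown cannot tell which of the two carries the step. On these data alone, a 4-nitrophenyl group set directly on the carbonyl carbon, or a (4-azidophenyl)amino group in the same place, would pull the two apart, and how a nitrile or a carboxylic acid on that ring would behave remains open.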